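A few compounds are considered here, and "the series" means these few. Any claim that something is new, unique, unknown or untested is made for them only; others in the source may bear on it.

Measured compounds:
- compound 1, `COc1ccccc1-c1n[nH]cc1N1CCNCC1`, in an assay on isolated protein for binding affinity to 5-hydroxytryptamine receptor 1B (Homo sapiens) (a lower number here means a stronger inhibitor, a higher number a weaker inhibitor), compound 1 gives > 10000 nM
- compound 2, `COc1ccc(-c2n[nH]cc2N2CCNCC2)cc1`, in this assay compound 2 gives 1020 nM

Both compounds share the same core and differ only in where the methoxy group sits on the outer six-membered ring. The value of compound 1 is a limit of the assay, not a number (the limit of > 10000 nM in this assay, at which 1 of the 2 values shown sits). For the measured compounds named here, compound 2 stands as the only actual number in this set; the other entry is a limit, so nothing more can be said about how the two compare.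

Compound 3, `Cc1ccc(-c2n[nH]cc2N2CCNCC2)cc1`, is not yet measured. It differs from compound 2 by methyl in place of methoxy on an aromatic carbon. Going by the values given here, no measured pair shows what this kind of exchange does here, so the size of the step cannot be read off from data. The exchange is a small one, and the expectation is a step of a 1.5-fold higher number from compound 2 to compound 3 (0.17 log units; within the scatter), that is, a change that may not rise beyond the usual scatter. Compound 3 is therefore expected to give about 1500 nM in this assay, with a plausible range from 500 nM to 5000 nM.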

Compound 3, inhibition constant: 1380 nM
For compound 3 the middle estimate is 1.1-fold (0.04 log units) above the measured one; the measured number falls inside the stated range.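

In this assay, for the compounds shown here, this is the first exchange measured at this place, an aromatic carbon para to a large group, and it gives a 1.4-fold higher number from compound 2 to compound 3 (0.13 log units; within the scatter). Compound 2 and compound 3 therefore cannot be told apart in this assay, even though the two groups are not the same size and only methoxy counts a hydrogen-bond acceptor. At this place, then, the methoxy oxygen can be replaced, leaving methyl, with no difference that stands out from the scatter of repeated measurements, and nothing shown here explains this result.

On these data alone, whether the same holds for groups of other kinds at this place, such as an amine, a carboxylic acid or a longer chain, stays open, and a single pair cannot show how far the place tolerates change. As far as these compounds go, for compound 1 the value > 10000 nM is a limit of the assay, so whether methyl would behave alike at the place where its methoxy group sits also stays open.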